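The source may hold more compounds than are shown below. What is called first, only, known or untested is meant among the compounds shown, and "the series" means these compounds.

Among the measured compounds shown here, in a functional assay on MOLT-4 cells (Homo sapiens) for cytotoxicity (a lower number here means that less compound is tolerated, a higher number that more compound is tolerated), compound 2 `C=CCNc1nc(N)nc2c1ncn2C1CC(O)C(CO)S1` gives 40000 nM, the higher of the two numbers known so far. Compound 3 `Nc1nc(O)c2ncn(C3CC(O)C(CO)S3)c2n1` keeps the shared core but changes one group: hydroxy in place of allylamino on an aromatic carbon. For the measured compounds named here, one measured step bears on this change, the modest 3.1-fold higher number from compound 1 to compound 2 (0.49 log units; beyond the scatter), where allylamino replaced cyclopropylmethoxy on that carbon. Compound 1 `Nc1nc(OCC2CC2)c2ncn(C3CC(O)C(CO)S3)c2n1`, also joined through oxygen there, sits lower at 13000 nM, so a similar modest move to a lower number is expected. The estimated change is a 3.3-fold lower number from compound 2 to compound 3 (0.52 log units; beyond the scatter). For compound 3 the expected value is 12000 nM, within an estimated range of 1500 nM to 60000 nM.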

Compound 3, half-maximal cytotoxic concentration: 14000 nM
Estimate against measurement, compound 3: 1.2-fold (0.07 log units) below, within the range that was stated.
By their numbers in this assay, from the lowest: compounds 1 and 3 (each within the scatter of the next); then compound 2.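

In this assay, hydroxy in place of allylamino on this aromatic carbon gives a 2.9-fold lower number from compound 2 to compound 3 (0.46 log units; beyond the scatter) and so shows that the higher number of compound 2 does not carry over to hydroxy. Hydrogen in place of cyclopropylmethyl on the oxygen gives a 1.1-fold higher number from compound 1 to compound 3 (0.03 log units; within the scatter) and so leaves the two oxygen-linked compounds indistinguishable here, with only allylamino standing apart among the three. Nothing measured here offers an explanation for this. The compounds shown leave open whether the nitrogen link or the allyl chain sets compound 2 apart, a question that a plain amino group or a propylamino chain on this carbon could address.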